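Swapping Methyl for 3-Aminophenyl on the Ether Linker

A few compounds are considered here, and "the series" means these few. Any claim that something is new, unique, unknown or untested is made for them only; others in the source may bear on it.

Compound 1 `Nc1ccccc1COc1ccc(OCCOCCNC2CCCC2)cc1` gives 14000 nM in a functional assay on SK-OV-3 cells (Homo sapiens) for inhibition, read by CCK-8 assay, with a stated time of 70 h; a lower number here means a stronger inhibitor, a higher number a weaker inhibitor.
Compound 2 `CCOc1ccc(OCCOCCNC2CCCC2)cc1` gives 90500 nM in this assay.

Of the two measured numbers, compound 2 holds the higher one and is therefore the weaker inhibitor of the pair. Within the data shown here, the single measured step is a 6.5-fold higher number from compound 1 to compound 2 (0.81 log units; beyond the scatter), a modest but real loss when the 2-aminophenyl group gives way to methyl.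

Compound 3 `Nc1cccc(COc2ccc(OCCOCCNC3CCCC3)cc2)c1` differs from compound 2 in exactly one place: 3-aminophenyl in place of methyl on a saturated chain carbon bound to an oxygen on an aromatic ring. Among the measured compounds shown here, the change runs in the opposite direction to the one step already measured, with the amine now on the 3-position of the ring instead of the 2-position. For the measured compounds named here, that measured step is the only guide: read backwards, it says that placing an aminophenyl on this chain carbon lowered the number well beyond the scatter. Whether the 3-aminophenyl behaves like the 2-aminophenyl is not told by these data, so the expectation is a gain of roughly the same size in this assay, with wide uncertainty. Compound 3 is therefore expected near 16000 nM, within 5000 nM to 50000 nM. This expected change is a 5.7-fold lower number from compound 2 to compound 3 (0.75 log units; beyond the scatter).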

Compound 3, half-maximal inhibitory concentration: 10800 nM
Compound 3: middle estimate off by 1.5-fold (0.17 log units), on the high side, and the stated range covers the measured number.
By their numbers in this assay, from the lowest: compounds 3 and 1 (each within the scatter of the next); then compound 2.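

In this assay, the gain over methyl is not confined to the 2-aminophenyl group: the change to 3-aminophenyl gives an 8.4-fold lower number from compound 2 to compound 3 (0.92 log units; beyond the scatter), so a second aminophenyl group on this saturated chain carbon also lowers the number beyond the scatter. Moving from one aminophenyl group to the other gives a 1.3-fold lower number from compound 1 to compound 3 (0.11 log units; within the scatter), which means that the two compounds cannot be told apart here and that this pair shows no preference for either group. Nothing measured here explains these steps.

As far as these compounds go, whether the gain comes from the aromatic ring itself or from its amine stays open: a plain phenyl group on the same carbon, or a phenyl ring carrying a hydroxyl or a carboxylic acid instead of the amine, would separate the two. Also open, from the compounds shown here alone, is whether the same gain would appear on a changed version of the shared core, for instance one with a longer chain in place of the ether chain that these compounds have in common.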